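This account rests on a few compounds, and the source may have more. Where it says the series, first, only, none or still open, it means among the compounds named here.

Compound 1 `O=C(O)CNC(=O)COc1ccc([C@H]2CC[C@]3(CC2)OOC2(O3)C3CC4CC(C3)CC2C4)cc1` is the only one of the three measured compounds that gives an actual number in a physicochemical assay for solubility, read by nephelometry, in phosphate buffer, measured as kinetic solubility, with a stated time of 30 min, at pH 6.5; on this read-out higher numbers stand for higher solubility and lower numbers for lower solubility; in that assay compound 1 gives 12.5 ug/mL. Compound 2 `O=C(O)COc1ccc([C@H]2CC[C@]3(CC2)OOC2(O3)C3CC4CC(C3)CC2C4)cc1C(=O)O` sits at the limit of the assay, where compound 2 reads < 3.1 ug/mL. Compound 3 `O=C(O)COc1ccc([C@H]2CC[C@]3(CC2)OOC2(O3)C3CC4CC(C3)CC2C4)cc1Cl` also sits at the limit of the assay, with compound 3 reading < 3.1 ug/mL. Among the measured compounds shown here, the one measured step, a step that the two limits leave unreadable from compound 2 to compound 3, runs between two limits and so gives no size at all. Compound 4 `CCOC(=O)COc1ccc([C@H]2CC[C@]3(CC2)OOC2(O3)C3CC4CC(C3)CC2C4)cc1` differs from compound 1 in one place: ethoxy in place of (carboxymethyl)amino on a carbonyl carbon. For the measured compounds named here, no measured step mirrors this change, so there is nothing to copy directly; what the data do show is that two of the three values sit at the limit of < 3.1 ug/mL in this assay, at which 2 of the 3 values shown sit, and compound 1 alone rises clearly out of that region. Compound 4 is expected to lose solubility relative to compound 1, an estimated step of a 4.2-fold lower number from compound 1 to compound 4 (0.62 log units; beyond the scatter), and may well be reported only as a limit. For compound 4 the estimate in this assay is 3 ug/mL, within a range from 1 ug/mL to 8 ug/mL.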

Compound 4, solubility: < 1.6 ug/mL
Compound 4 gave a limit, no number; the forecaster's own chance of this, stated with the estimate: 65%; middle value at least 1.8-fold (0.27 log units) away from the limit.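

In this assay, among the compounds shown here, this is the first change with a readable size, since the one earlier step runs between two limits and cannot be read. Putting ethoxy in place of (carboxymethyl)amino on a carbonyl carbon gives an at least 7.8-fold lower number from compound 1 to compound 4 (0.89 log units; beyond the scatter), so on the shared core the group at this carbonyl carbon clearly matters to the read-out. The result for compound 4 is a limit and not a number, so this step gives only a minimum size: the limit of < 1.6 ug/mL in this assay, at which 1 of the 4 values shown sits.

A single swap leaves open which part of (carboxymethyl)amino carries the difference, the nitrogen with its hydrogen or the carboxylic acid at its end. A plain amino group or a hydroxy on this carbonyl carbon, or a longer chain ending in a carboxylic acid, would help to separate the two.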